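Turning the Amide Around in Compound 1

A few compounds are considered here, and "the series" means these few. Any claim that something is new, unique, unknown or untested is made for them only; others in the source may bear on it.

Compound 1 `CNC(=O)c1cc(C)n(Cc2cc(Cl)ccc2OCc2ccccc2)n1`: 100 nM
Compound 2 `Cc1cc(C(=O)NC(C)C)nn1Cc1cc(Cl)ccc1OCc1ccccc1`: 126 nM
Compound 3 `Cc1cc(C(=O)NCc2ccncc2)nn1Cc1cc(Cl)ccc1OCc1ccccc1`: 79.4 nM

In an assay on CHO-K1 cells for displacement of a labelled ligand from prostaglandin E2 receptor EP1 subtype (Homo sapiens) (on this read-out lower numbers stand for stronger inhibition and higher numbers for weaker inhibition), compound 1 gives 100 nM, the second highest of the three numbers. Its nearest neighbour, compound 3, gives 79.4 nM; compound 2 gives 126 nM. The three measured steps, a 1.3-fold higher number from compound 1 to compound 2 (0.10 log units; within the scatter), a 1.3-fold lower number from compound 1 to compound 3 (0.10 log units; within the scatter) and a 1.6-fold lower number from compound 2 to compound 3 (0.20 log units; within the scatter), all lie within the scatter, and all three change only the group on the amide nitrogen.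

Compound 4 `Cc1cc(NC(=O)C2CCCC2)nn1Cc1cc(Cl)ccc1OCc1ccccc1` takes a different route: (cyclopentylcarbonyl)amino in place of methylcarbamoyl on an aromatic carbon. Here the amide itself is turned around on the shared core and the carbonyl now carries a five-membered ring of carbon, so none of the measured steps bears directly on this change; they show only that what hangs on the amide nitrogen has mattered little so far. Compound 4 is therefore expected to give 250 nM, with a range of 60 nM to 1500 nM. That estimate means a 2.5-fold higher number from compound 1 to compound 4 (0.40 log units; beyond the scatter), a step expected to fall near the scatter but with real uncertainty in either direction.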

Compound 4, half-maximal inhibitory concentration: 15.9 nM
Compound 4: the middle estimate sits 16-fold (1.20 log units) above what was measured, and the stated range ends above it.
By their numbers in this assay, from the lowest: compound 4; then compounds 3, 1 and 2 (each within the scatter of the next).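

In this assay, going by these compounds alone, the steps of a 6.3-fold lower number from compound 1 to compound 4 (0.80 log units; beyond the scatter) and a 5.0-fold lower number from compound 3 to compound 4 (0.70 log units; beyond the scatter) and a 7.9-fold lower number from compound 2 to compound 4 (0.90 log units; beyond the scatter) are the first in this set to lie beyond the scatter. The three amide nitrogen groups of compound 1, compound 2 and compound 3 stayed within the scatter of one another, whereas (cyclopentylcarbonyl)amino on this aromatic carbon gives a clear separation from all three. No measured evidence here accounts for that separation.

The single change turns the amide around and also brings in the five-membered ring of carbon, so the compounds shown cannot tell which of the two carries the step. Also open, as far as these compounds go, is how the turned-around amide would read with an acetyl group, a cyclohexane ring or a phenyl ring in place of the cyclopentane ring on its carbonyl.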